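Pendant phenyl substituent: ester replaced by vinyl

This account rests on a few compounds, and the source may have more. Where it says the series, first, only, none or still open, it means among the compounds named here.

Compound 1 `COc1cc(-c2ccnc3cc(-c4ccc5cc[nH]c5c4)nn23)cc(OC)c1OC` carries 1H-indol-6-yl on the shared core, and in a functional assay on MCF7 cells (Homo sapiens) for inhibition, read by CCK-8 assay, with a stated time of 48 h (a lower number here means a stronger inhibitor, a higher number a weaker inhibitor), compound 1 gives 23 nM. Compound 2 `COc1cc(-c2ccnc3cc(-c4ccc(C(C)=O)cc4)nn23)cc(OC)c1OC` gives 5230 nM, so that a 230-fold higher number from compound 1 to compound 2 (2.36 log units; beyond the scatter). Compound 3 `CCOC(=O)c1ccc(-c2cc3nccc(-c4cc(OC)c(OC)c(OC)c4)n3n2)cc1` reaches only a limit of the assay, > 10000 nM. For compound 3 the number is therefore not known beyond (the limit of > 10000 nM in this assay, at which 1 of the 3 values shown sits), and the step of an at least 1.9-fold higher number from compound 2 to compound 3 (0.28 log units; that floor lies within the scatter) does not separate the two compounds.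

Compound 4 `C=Cc1ccc(-c2cc3nccc(-c4cc(OC)c(OC)c(OC)c4)n3n2)cc1` differs from compound 3 by vinyl in place of ethoxycarbonyl on an aromatic carbon. Among the measured compounds shown here, no measured step removes the whole ethoxycarbonyl in favour of a hydrocarbon group. For the measured compounds named here, the nearest comparison is an at least 1.9-fold higher number from compound 2 to compound 3 (0.28 log units; that floor lies within the scatter), within the scatter, while the only large step, a 230-fold higher number from compound 1 to compound 2 (2.36 log units; beyond the scatter), concerns the group on the other side of the core. Since compound 3 sits at a limit, the step of an at least 1.6-fold lower number from compound 3 to compound 4 (0.22 log units; that floor lies within the scatter) is estimated with little anchoring, and a number rather than a limit is expected more often than not. Compound 4 is expected to give 6000 nM, within a range of 1500 nM to 25000 nM.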

Compound 4, half-maximal inhibitory concentration: 193 nM
Compound 4: middle estimate off by 31-fold (1.49 log units), on the high side; measured number outside the range, below it.
By their numbers in this assay, from the lowest: compound 1; then compound 4; then compound 2. At a limit, above all of these: compound 3.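

Vinyl at this place, para to a large group, stands well apart from both carbonyl-bearing groups in this assay: acetyl gives way to vinyl in a large step (a 27-fold lower number from compound 2 to compound 4 (1.43 log units; beyond the scatter)), and ethoxycarbonyl gives way to vinyl in another (an at least 51-fold lower number from compound 3 to compound 4 (1.71 log units; beyond the scatter)). Compound 3 is held at a limit, so the second step gives only a floor: the limit of > 10000 nM in this assay, at which 1 of the 4 values shown sits. A substituted phenyl group therefore need not lose as much against 1H-indol-6-yl as the acetyl comparison suggested, although a modest gap remains (an 8.4-fold higher number from compound 1 to compound 4 (0.92 log units; beyond the scatter)).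

Going by these compounds, whether the double bond of the vinyl group matters, or only the absence of a carbonyl, stays open, and an ethyl group at this place would bear on that. On these data alone, the effect of a longer chain, an amine or a carboxylic acid here also remains open.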